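This account rests on a few compounds, and the source may have more. Where it says the series, first, only, none or still open, it means among the compounds named here.

Going by the values given here, in a functional assay on PC-3 cells (Homo sapiens) for antiproliferative activity (on this read-out lower numbers stand for stronger inhibition of growth and higher numbers for weaker inhibition of growth), compound 1 `Cc1cc(C)c2c(O)cc(-c3cccc(F)c3)nc2n1` gives 61.7 nM, the lower of the two actual numbers so far. Compound 3 `Cc1cc(C)c2c(O)cc(-c3ccc4ccccc4c3)nc2n1`, which shares its core, gives 5500 nM, a gap well beyond the scatter. Compound 2 `Cc1cnc2[nH]c(-c3cccc(Cl)c3)cc(=O)c2c1` is recorded only as a limit, > 100000 nM. Compound 4 `Cc1cccc(-c2cc(O)c3c(C)cc(C)nc3n2)c1` differs from compound 1 by methyl in place of fluoro on an aromatic carbon, meta to a large group: methyl in place of fluoro on an aromatic carbon. Among the compounds with values here, no measured pair isolates this kind of change. With compound 1 at 61.7 nM, the lowest number, a moderate rise in this assay is expected, reaching somewhat beyond the scatter. The estimated step is a 3.2-fold higher number from compound 1 to compound 4 (0.51 log units; beyond the scatter), toward weaker inhibition of growth. For compound 4 the estimated value is 200 nM, within an expected range of 40 nM to 1500 nM.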

Compound 4, concentration for 50% growth inhibition: 31600 nM
For compound 4 the middle estimate is 160-fold (2.20 log units) below the measured one; the measured number lies above the stated range.
By their numbers in this assay, from the lowest: compound 1; then compound 3; then compound 4. At a limit, above all of these: compound 2.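

At this aromatic carbon, meta to a large group, the change is far from neutral in this assay: methyl in place of fluoro gives a 510-fold higher number from compound 1 to compound 4 (2.71 log units; beyond the scatter). An exchange of one heavy atom, with no hydrogen-bond donor or acceptor on either side, is thus enough for a large loss of growth inhibition. Compound 4 still gives an actual number, and only compound 2 is recorded as a limit: the limit of > 100000 nM in this assay, at which 1 of the 4 values shown sits.

The compounds shown do not separate a penalty for methyl from a specific benefit of fluoro. As far as these compounds go, how a methoxy group, an amine or plain hydrogen would fare at this place remains open.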